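The compounds below may be only part of what the source reports. "The series", "measured", "known", "first", "only" and "open" are said of these compounds alone.

Among the measured compounds shown here, compound 2 `Cc1ccc(C(=O)O)cc1OCCCCOc1ccc(C(=O)CC(C)C)c(O)c1C` stands lowest of the two numbers so far in an assay on HEK293 cells for positive allosteric modulation of metabotropic glutamate receptor 3 (Rattus norvegicus), read by thallium flux, with a stated time of 2.5 min (on this read-out higher numbers stand for larger maximal responses and lower numbers for smaller maximal responses), where compound 2 gives 29.4%. Compound 1 `Cc1c(OCCCCOc2cccc(C(=O)O)c2)ccc(C(=O)CC2CCCC2)c1O` gives 92.9% in this assay, a number beyond the scatter above compound 2. Compound 3 `Cc1c(OCCCCOc2cccc(C(=O)O)c2)ccc(C(=O)CC(C)C)c1O` differs from compound 2 by hydrogen in place of methyl on an aromatic carbon, which cut one bond further out reads 5-carboxy-2-methylphenyl to 3-carboxyphenyl, the acid-bearing ring that compound 1 also carries. For the measured compounds named here, no measured pair shows this change directly; a rise beyond the scatter is expected, with a step of a number 35.6 percentage points higher from compound 2 to compound 3 (beyond the scatter). Compound 3 is expected to reach 65%, within 35% to 95%.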

Compound 3, largest response reached (reported as percent of maximum), in percent of the reference or control that the assay uses: 69.9%
The estimate for compound 3 lay 4.9 percentage points below the measured number, and the stated range covers the measured number.
By their numbers in this assay, from the lowest: compound 2; then compound 3; then compound 1.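

In this assay the methyl para to a carboxy group matters: hydrogen in its place gives a number 40.5 percentage points higher from compound 2 to compound 3 (beyond the scatter) and marks this aromatic carbon as a sensitive point in the acid-bearing ring. With 3-carboxyphenyl held constant, the other end of the molecule also counts, as isopropyl in place of cyclopentyl gives a number 23 percentage points lower from compound 1 to compound 3 (beyond the scatter) as a modest step. No measured finding here explains either step.

Still open, on these data alone, is how fluorine, chlorine or a methoxy group would read on this aromatic carbon. Also open, as far as these compounds go, is whether the methyl lowers the response as sharply with cyclopentyl on the chain.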